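Extending the Amide Aryl Group by an Ethenyl Link

This account rests on a few compounds, and the source may have more. Where it says the series, first, only, none or still open, it means among the compounds named here.

Compound 1, `COc1ccc(C(=O)NC[C@H]2c3[nH]c4ccccc4c3C[C@H]3[C@H]4c5[nH]c6ccccc6c5C[C@@H]([C@H](C#N)N23)N4C)cc1`: 320 nM
Compound 2, `CN1[C@@H]2c3[nH]c4ccccc4c3C[C@H]1[C@H](C#N)N1[C@@H](CNC(=O)c3ccc(F)cc3)c3[nH]c4ccccc4c3C[C@@H]21`: 250 nM
Compound 3, `CN1[C@@H]2c3[nH]c4ccccc4c3C[C@H]1[C@H](C#N)N1[C@@H](CNC(=O)c3cc4ccccc4o3)c3[nH]c4ccccc4c3C[C@@H]21`: 230 nM

The three compounds share a core and differ only in the group on the amide carbonyl. In a functional assay on A2780 cells (Homo sapiens) for cytotoxicity, read by MTT assay, with a stated time of 72 h (on this read-out lower numbers stand for stronger inhibition and higher numbers for weaker inhibition), compound 1 has the highest of the three numbers, yet its steps to the others, a 1.3-fold lower number from compound 1 to compound 2 (0.11 log units; within the scatter) and a 1.4-fold lower number from compound 1 to compound 3 (0.14 log units; within the scatter), are within the scatter, as is a 1.1-fold lower number from compound 2 to compound 3 (0.04 log units; within the scatter). None of these changes to the aryl group moved the number beyond the scatter.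

Compound 4, `COc1ccc(/C=C/C(=O)NC[C@H]2c3[nH]c4ccccc4c3C[C@H]3[C@H]4c5[nH]c6ccccc6c5C[C@@H]([C@H](C#N)N23)N4C)cc1`, has not yet been measured. It differs from compound 1 by 2-(4-methoxyphenyl)ethenyl in place of 4-methoxyphenyl on a carbonyl carbon. Among the measured compounds shown here, no measured step inserts a double bond between the carbonyl and the aryl ring, so none bears directly on it; the steps that do exist show only that varying the group on the carbonyl left the number roughly unchanged. The expectation is therefore a step of a 1.1-fold lower number from compound 1 to compound 4 (0.03 log units; within the scatter), no change beyond the scatter, with wide uncertainty. Compound 4 is estimated at 300 nM, between 110 nM and 850 nM.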

Compound 4, half-maximal inhibitory concentration: 860 nM
Compound 4: the middle estimate sits 2.9-fold (0.46 log units) below what was measured, outside the stated range (above it).
By their numbers in this assay, from the lowest: compounds 3, 2 and 1 (each within the scatter of the next); then compound 4.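

In this assay the group on the carbonyl carbon proved able to move the number beyond the scatter, with a 2.7-fold higher number from compound 1 to compound 4 (0.43 log units; beyond the scatter) on adding the ethenyl link, whereas the earlier exchanges of aryl groups had all stayed within it. The 2-(4-methoxyphenyl)ethenyl group also stands apart from the other two groups, with a 3.4-fold higher number from compound 2 to compound 4 (0.54 log units; beyond the scatter) and a 3.7-fold higher number from compound 3 to compound 4 (0.57 log units; beyond the scatter) as well, so in this one case the longer group went with weaker inhibition. Nothing available accounts for this loss.

A 2-(4-methoxyphenyl)ethyl group on the carbonyl carbon would separate the double bond from the added length, and the compounds shown do not settle which of the two goes with the higher number. Nor do they tell whether a 2-(4-fluorophenyl)ethenyl group would behave the same way.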